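The compounds below may be only part of what the source reports. "The series", "measured", "known", "first", "only" and "open" are said of these compounds alone.

Compound 1 `COc1ccc(CNc2nc3cc(N)cc(N)c3nc2-c2ccccc2)cc1OC`: 6760 nM
Compound 2 `Nc1cc(N)c2nc(-c3ccccc3)c(NCc3ccc(F)cc3)nc2c1`: 2630 nM

Among the compounds with values here, in a functional assay on OVCAR-8 cells (Homo sapiens) for inhibition, read by sulforhodamine B assay, with a stated time of 48 h (on this read-out lower numbers stand for stronger inhibition of growth and higher numbers for weaker inhibition of growth), compound 2 holds the lower of the two numbers, the only measured step being a 2.6-fold lower number from compound 1 to compound 2 (0.41 log units; beyond the scatter). Compound 3 `COc1ccc(CNc2nc3cc(N)cc(N)c3nc2-c2ccccc2)cc1` differs from compound 2 by methoxy in place of fluoro on an aromatic carbon. Within the data shown here, only that one step bears on this change, and it swapped two methoxy groups for a single fluorine, so the return of one methoxy is expected to move the number part of the way back toward compound 1, as a 1.6-fold higher number from compound 2 to compound 3 (0.21 log units; within the scatter). Compound 3 is therefore estimated at 4300 nM, within 2000 nM to 9500 nM.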

Compound 3, concentration for 50% growth inhibition: 14800 nM
Estimate against measurement, compound 3: 3.4-fold (0.54 log units) below, and the stated range ends below it.
By their numbers in this assay, from the lowest: compound 2; then compound 1; then compound 3.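

Methoxy in place of fluoro gives a 5.6-fold higher number from compound 2 to compound 3 (0.75 log units; beyond the scatter) and so clearly weakens growth inhibition at this aromatic carbon. Hydrogen in place of the second methoxy of compound 1 gives a 2.2-fold higher number from compound 1 to compound 3 (0.34 log units; beyond the scatter) and leaves compound 3 above both other compounds rather than between them, so the two methoxy groups do not simply add up. No evidence on hand explains either step.

As far as these compounds go, it remains open whether chloro, hydroxy or an amine at this carbon would behave like fluoro or like methoxy.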